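Tolerance in cell viability across three analogues and one untested relative

The compounds below may be only part of what the source reports. "The series", "measured", "known", "first", "only" and "open" are said of these compounds alone.

The set comprises compound 1 `Cc1cc(C)nc(Sc2ccnc(Nc3ccc(C#N)cc3)n2)n1`, compound 2 `N#Cc1ccc(Nc2nccc(OCc3cccc(F)c3)n2)cc1` and compound 3 `COc1cc(COc2ccnc(Nc3ccc(C#N)cc3)n2)cc(OC)c1`, all measured in an ADME assay on MT4 cells (Homo sapiens) for cytotoxicity, read by MTT assay, with a stated time of 5 days; a lower number here means that less compound is tolerated, a higher number that more compound is tolerated. Compound 1 gives 224000 nM, compound 2 gives 105000 nM and compound 3 gives 44200 nM. Compound 2 thus stands second highest of the three numbers: compound 1 lies above it by a step beyond the scatter, and compound 3 lies below it by a step that is also beyond the scatter. No pair among these three differs in a single place, so none of these gaps can be tied to one structural change.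

Compound 4 `N#Cc1ccc(COc2ccnc(Nc3ccc(C#N)cc3)n2)cc1` is not yet measured. Among the compounds with values here, its only difference from compound 2 is 4-cyanophenyl in place of 3-fluorophenyl on a saturated chain carbon bound to an oxygen on an aromatic ring. Within the data shown here, with nothing among the measured compounds to anchor this change, a step from compound 2 to compound 4 of a 1.1-fold lower number from compound 2 to compound 4 (0.02 log units; within the scatter) is expected, which does not exceed the usual scatter, and its direction is not firm. Compound 4 is accordingly estimated at 100000 nM in this assay, with a range from 45000 nM to 220000 nM.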

Compound 4, half-maximal cytotoxic concentration: 209000 nM
Beside the measured number, compound 4's estimate is 2.1-fold (0.32 log units) below it, and the stated range covers the measured number.
By their numbers in this assay, from the lowest: compound 3; then compounds 2, 4 and 1 (each within the scatter of the next, the first and the last beyond it).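

Within the data shown here, compound 2 and compound 4 form the first pair that differs in a single place, so a step in this assay can now be tied to one structural change. Placing 4-cyanophenyl in place of 3-fluorophenyl on a saturated chain carbon bound to an oxygen on an aromatic ring gives a 2.0-fold higher number from compound 2 to compound 4 (0.30 log units; within the scatter) and so stays within the usual scatter, which means this read-out does not separate the two groups at this position. No measurement at hand offers a reason for this step.

This single pair does not show whether the same holds for groups of another kind at this position, such as a phenyl carrying an amine or a carboxylic acid. As far as these compounds go, a longer chain at the saturated chain carbon also remains open.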